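The source may hold more compounds than are shown below. What is called first, only, known or untested is meant among the compounds shown, and "the series" means these compounds.

Compound 2 `C=CS(=O)(=O)N1CCN(c2ncnc3sc(-c4ccc(N5CCN(C)CC5)cc4)cc23)CC1` carries, on the amine nitrogen of its six-membered ring with two nitrogens, a vinylsulfonyl group. In a functional assay on MDA-MB-231 cells (Homo sapiens) for antiproliferative activity, read by MTT assay, with a stated time of 48 h (a higher number here means a weaker inhibitor, a lower number a stronger inhibitor), compound 2 gives 7550 nM, the highest of the three numbers shown, though its nearest neighbour, compound 1 `C=CS(=O)(=O)N1CCN(c2ncnc3sc(-c4ccc(C(F)(F)F)cc4)cc23)CC1` at 6410 nM, and compound 3 `C=CS(=O)(=O)N1CCN(c2ncnc3sc(-c4ccc(N5CCN(C)CC5)cc4)cc23)[C@@H](C)C1` at 6180 nM both lie within the scatter of it: a 1.2-fold higher number from compound 1 to compound 2 (0.07 log units; within the scatter) and a 1.2-fold lower number from compound 2 to compound 3 (0.09 log units; within the scatter) are both small steps that do not separate the compounds.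

Compound 4 `CN1CCN(c2ccc(-c3cc4c(N5CCN(C(=O)Nc6ccc(F)cc6F)CC5)ncnc4s3)cc2)CC1` differs from compound 2 at a place that neither measured step touches: (2,4-difluorophenyl)carbamoyl in place of vinylsulfonyl on an amine nitrogen in a ring. The step from compound 1 to compound 2 altered the group on the aromatic ring attached to the core, and the step from compound 2 to compound 3 added a methyl on a saturated ring carbon; neither gives information about exchanging the vinylsulfonyl group itself. For the measured compounds named here, no measured step therefore bears on this change, and the expectation for compound 4 rests only on the narrow range of the three numbers so far, with wide uncertainty. Compound 4 is expected to give 7000 nM, within 1500 nM to 30000 nM in this assay, which corresponds to an estimated 1.1-fold lower number from compound 2 to compound 4 (0.03 log units; within the scatter).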

Compound 4, half-maximal inhibitory concentration: 11400 nM
Compound 4: the middle estimate sits 1.6-fold (0.21 log units) below what was measured; the range from low to high includes it.
By their numbers in this assay, from the lowest: compounds 3, 1, 2 and 4 (each within the scatter of the next).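

The group on the amine nitrogen of the six-membered ring with two nitrogens now has a measured step of its own: in this assay, putting (2,4-difluorophenyl)carbamoyl in place of vinylsulfonyl gives a 1.5-fold higher number from compound 2 to compound 4 (0.18 log units; within the scatter). The entering group has more heavy atoms, brings an aromatic ring and a hydrogen-bond donor, and has no sulfur, yet this exchange does not separate the two compounds, so the vinylsulfonyl group is not needed at this place for a number in this range. Nothing measured here accounts for this outcome or ties it to any property of either group.

The compounds shown leave open whether a small acetyl or methylsulfonyl group on this amine nitrogen, with neither a vinyl group nor an aromatic ring, would also stay in this range. They also leave open whether (2,4-difluorophenyl)carbamoyl gives a similar number when combined with trifluoromethyl in place of 4-methylpiperazin-1-yl on the aromatic ring, or with the added methyl on the saturated ring carbon.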